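A Methoxy Group Replaces Benzyl at One Place

The source may report more compounds than this note shows. Statements on the series, on what has been measured and on what is new or still open speak of the compounds shown alone.

In a functional assay on a cell-free system (plasma, Homo sapiens), with a stated time of 3 min (on this read-out higher numbers stand for weaker inhibition and lower numbers for stronger inhibition), compound 1 (`Cc1cccc([C@@H](O)C(=O)N2N=CC[C@H]2C(=O)NCc2cc(Cl)ccc2-n2cnnn2)c1`) gives 830 nM and compound 2 (`O=C(NCc1cc(Cl)ccc1-n1cnnn1)[C@@H]1CC=NN1C(=O)[C@H](O)Cc1ccccc1`) gives 1400 nM while compound 3 (`O=C(NCc1cc(Cl)ccc1-n1cnnn1)[C@@H]1C[C@H]2C[C@H]2N1C(=O)[C@H](O)c1cccc(F)c1`) gives 1100 nM with all three within the usual scatter of one another. Compound 2 therefore stands level with the other two. Compound 4 (`COC(C)(C)[C@@H](O)C(=O)N1N=CC[C@H]1C(=O)NCc1cc(Cl)ccc1-n1cnnn1`) carries 1-methoxy-1-methylethyl in place of benzyl on a saturated chain carbon bound to a carbonyl carbon and an oxygen on a saturated carbon. Within the data shown here, the only measured change at this place is a 1.7-fold higher number from compound 1 to compound 2 (0.23 log units; within the scatter) and it stays within the scatter. Among the measured compounds shown here, no measured compound carries the entering group, so the range must stay wide. An estimated 1.3-fold higher number from compound 2 to compound 4 (0.11 log units; within the scatter) is expected in this assay and this lies within the scatter. Compound 4 is estimated at 1800 nM within an expected range of 600 nM to 5400 nM on this read-out.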

Compound 4, half-maximal inhibitory concentration: 3700 nM
Beside the measured number, compound 4's estimate is 2.1-fold (0.31 log units) below it; low and high end bracket the measured number.
By their numbers in this assay, from the lowest: compounds 1, 3 and 2 (each within the scatter of the next); then compound 4.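

In this assay this position shows its first steps beyond the scatter: 1-methoxy-1-methylethyl, which carries no ring, gives a 2.6-fold higher number from compound 2 to compound 4 (0.42 log units; beyond the scatter) in place of benzyl and a 4.5-fold higher number from compound 1 to compound 4 (0.65 log units; beyond the scatter) in place of 3-methylphenyl. Both steps are modest and both run toward weaker inhibition, so this place does respond to a change of group. Nothing given here bears on the cause of this change. The compounds shown leave open whether the missing ring or the methoxy oxygen goes with the step, and how a plain tert-butyl group or an amine would read at this place.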